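A longer alkenyl chain on the amide of compound 3

A few compounds are considered here, and "the series" means these few. Any claim that something is new, unique, unknown or untested is made for them only; others in the source may bear on it.

Compound 3 `C=CC(=O)Nc1cc(Nc2nc(C)cc(-c3cn(C)c4ccccc34)n2)c(OC)cc1N(C)CCN(C)C` gives 12600 nM in a functional assay on HepG2 cells (Homo sapiens) for antiproliferative activity, read by MTT assay, with a stated time of 72 h (on this read-out higher numbers stand for weaker inhibition and lower numbers for stronger inhibition), the highest number of the three measured; compound 1 `COc1cc(N(C)CCN(C)C)c(NC(=O)C=C(C)C)cc1Nc1nccc(-c2cn(C)c3ccccc23)n1` gives 5660 nM and compound 2 `CCC/C=C\C(=O)Nc1cc(Nc2nccc(-c3cn(C)c4ccccc34)n2)c(OC)cc1N(C)CCN(C)C` gives 431 nM. Compound 4 `CC/C=C\C(=O)Nc1cc(Nc2nc(C)cc(-c3cn(C)c4ccccc34)n2)c(OC)cc1N(C)CCN(C)C` differs from compound 3 by but-1-en-1-yl in place of vinyl on a carbonyl carbon. Among the measured compounds shown here, the one measured step that bears on this is a 13-fold lower number from compound 1 to compound 2 (1.12 log units; beyond the scatter), where pent-1-en-1-yl took the place of 2-methylprop-1-en-1-yl on a carbonyl carbon. That step was large, and compound 4 likewise carries a longer alkenyl chain on the carbonyl carbon, so a lower number is expected for compound 4, though not necessarily by as much, since the change starts from vinyl rather than from a branched group. Compound 4 is therefore estimated at 2500 nM, between 800 nM and 8000 nM. This estimate means an expected step of a 5.0-fold lower number from compound 3 to compound 4 (0.70 log units; beyond the scatter).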

Compound 4, half-maximal inhibitory concentration: 2050 nM
Compound 4: the middle estimate sits 1.2-fold (0.09 log units) above what was measured; the range from low to high includes it.
By their numbers in this assay, from the lowest: compound 2; then compound 4; then compound 1; then compound 3.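

In this assay, but-1-en-1-yl in place of vinyl on a carbonyl carbon gives a 6.1-fold lower number from compound 3 to compound 4 (0.79 log units; beyond the scatter), so a longer alkenyl chain at this place lowers the number even when the starting group is the unbranched vinyl. Alongside a 13-fold lower number from compound 1 to compound 2 (1.12 log units; beyond the scatter), this makes two steps in the same direction, each on its own core. No measured evidence accounts for either step. As far as these compounds go, whether pent-1-en-1-yl would lower the number further on the core of compound 4 remains open. So does whether a chain ending in an amine would keep the gain.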